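One Ring Swap Tried on Two Related Cores

The source may report more compounds than this note shows. Statements on the series, on what has been measured and on what is new or still open speak of the compounds shown alone.

Compound 1 `COc1cc(C=C(C(=O)/C=C/c2cccc(OC)c2OC)C(=O)/C=C/c2cccc(OC)c2OC)cc(OC)c1O` and compound 2 `COc1ccc(C=C(C(=O)/C=C/c2cccc(OC)c2OC)C(=O)/C=C/c2cccc(OC)c2OC)cc1O` share one core, while compound 3 `COc1ccc(/C=C/C(=O)C(=Cc2cc(OC)c(O)c(OC)c2)C(=O)/C=C/c2ccc(OC)cc2OC)c(OC)c1` and compound 4 `COc1ccc(/C=C/C(=O)C(=Cc2ccc(OC)c(O)c2)C(=O)/C=C/c2ccc(OC)cc2OC)c(OC)c1` share another that is built from the same atoms joined differently; that difference between the two cores is not broken down here. In a functional assay on CNE-2 cells (Homo sapiens) for antiproliferative activity, read by sulforhodamine B assay, with a stated time of 48 h (on this read-out higher numbers stand for weaker inhibition and lower numbers for stronger inhibition), compound 1 gives 300 nM, and compound 2 gives 220 nM. The change between them, (3-hydroxy-4-methoxyphenyl in place of 4-hydroxy-3,5-dimethoxyphenyl on a double-bonded chain carbon bound to a double-bonded chain carbon), gave a 1.4-fold lower number from compound 1 to compound 2 (0.13 log units; within the scatter). In this assay compound 3 gives 850 nM. Compound 4 carries the same change on the other core, (3-hydroxy-4-methoxyphenyl in place of 4-hydroxy-3,5-dimethoxyphenyl on a double-bonded chain carbon bound to a double-bonded chain carbon), and this change appears in only these two pairs. Because the step of a 1.4-fold lower number from compound 1 to compound 2 (0.13 log units; within the scatter) was small, compound 4 is expected to move by about as much, a 1.4-fold lower number from compound 3 to compound 4 (0.15 log units; within the scatter). Compound 4 is thus estimated at 600 nM, with a likely range from 300 nM to 1300 nM.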

Compound 4, half-maximal inhibitory concentration: 760 nM
Estimate against measurement, compound 4: 1.3-fold (0.10 log units) below; measured number inside the range.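

The same swap on the second core, 3-hydroxy-4-methoxyphenyl in place of 4-hydroxy-3,5-dimethoxyphenyl, gave a 1.1-fold lower number from compound 3 to compound 4 (0.05 log units; within the scatter) in this assay. Set beside the step on the first core, the two results do not differ: the same change on two cores in this assay, a 1.4-fold lower number (0.13 log units; within the scatter) from compound 1 to compound 2 and a 1.1-fold lower number (0.05 log units; within the scatter) from compound 3 to compound 4, 1.2-fold (0.09 log units) apart, within the scatter of two such steps In these two pairs, then, the swap carried over from one core to the other as a step too small to read, but a step this small cannot show that a larger shift would also carry over, and two pairs make no general rule.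

From the compounds shown here alone, whether a ring bearing an amine or a carboxylic acid in the same place would behave alike on both cores stays open. So does whether the swap would behave the same way in other cell lines.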